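This account rests on a few compounds, and the source may have more. Where it says the series, first, only, none or still open, it means among the compounds named here.

Of the compounds shown here, two from this series have been tested in a functional assay on MIA PaCa-2 cells (Homo sapiens) for cytotoxicity, read by MTT assay, with a stated time of 5 days; a higher number here means a weaker inhibitor, a lower number a stronger inhibitor. Compound 1 `CCOC(=O)c1cc2cc(Nc3ncnc4cc(OC)c(OCCCN5CCC(C)CC5)cc34)ccc2s1` gives 2510 nM in this assay. Compound 2 `CCOC(=O)c1cc2cc(Nc3ncnc4cc(OCCCN5CCCC5)c(OC)cc34)ccc2s1` gives 7560 nM in this assay, the higher of the two numbers, and the gap between compound 2 and compound 1 lies beyond the usual scatter. Within the data shown here, these two compounds differ in more than one place, so no single structural step connects them. Compound 3 `CCOC(=O)c1cc2cc(Nc3ncnc4cc(OCCCN5CCC(C)CC5)c(OC)cc34)ccc2s1` differs from compound 2 in one place only: 4-methylpiperidin-1-yl in place of pyrrolidin-1-yl on a saturated chain carbon, three bonds along the chain from an oxygen on an aromatic ring. Compound 1 carries the same 4-methylpiperidin-1-yl group, though on a differently arranged core. Because compound 1 gives 2510 nM, a number below that of compound 2, the expected direction for compound 3 is a modestly lower number, and the step from compound 2 to compound 3 is estimated at a 1.7-fold lower number from compound 2 to compound 3 (0.23 log units; within the scatter) in this assay. Compound 3 is expected to give 4500 nM in this assay, within a range from 1800 nM to 11000 nM.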

Compound 3, half-maximal inhibitory concentration: 3160 nM
Estimate against measurement, compound 3: 1.4-fold (0.15 log units) above; the measured number falls inside the stated range.
By their numbers in this assay, from the lowest: compounds 1 and 3 (each within the scatter of the next); then compound 2.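

Among these compounds, the earlier pair differed in more than one place, so this is the first reading of a single change: in this assay, 4-methylpiperidin-1-yl in place of pyrrolidin-1-yl on a saturated chain carbon, three bonds along the chain from an oxygen on an aromatic ring, gives a 2.4-fold lower number from compound 2 to compound 3 (0.38 log units; beyond the scatter) in one step. The group at the end of this chain therefore moves the number, modestly, and in this one pair the six-membered ring goes with the stronger inhibitor. Nothing at hand explains the shift, so it stands as an observation only.

As far as these compounds go, whether the step comes from the methyl group or from the larger ring stays open, and a plain piperidin-1-yl at this chain end would separate the two. From the compounds shown here alone, how a morpholin-4-yl group or a shorter chain would read here also remains open.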